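Swapping a sulfur-bearing group for an allyl group

The compounds below may be only part of what the source reports. "The series", "measured", "known", "first", "only" and "open" are said of these compounds alone.

Compound 1 `CSC(CCC/C=C(\c1ccccc1)c1cccnc1)C(=O)O`: 30 nM
Compound 2 `O=C(O)CCCC/C=C(\c1cccnc1)c1cccs1`: 20 nM

Of the compounds shown here, two have been measured in an assay (Equus caballus) for inhibition of Thromboxane-A synthase (Homo sapiens), using microsomes; on this read-out lower numbers stand for stronger inhibition and higher numbers for weaker inhibition. Compound 1 gives 30 nM and compound 2 gives 20 nM. Compound 1 has the higher of the two numbers, but the gap to compound 2 is within the usual scatter of repeated measurements, so the two are best read as equally potent. Among the compounds with values here, the two compounds differ in more than one place, so no single step between them is counted here.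

Compound 3 `C=CCC(CCC/C=C(\c1ccccc1)c1cccnc1)C(=O)O` is not yet measured. It shares the core of compound 1 and differs in one place: allyl in place of methylsulfanyl on a saturated chain carbon bound to a carbonyl carbon and a saturated chain carbon. Within the data shown here, no step between measured compounds of this kind is available to anchor an expectation, and the only measured pair, compound 1 and compound 2, shows no change beyond the scatter.

The expected step is a 1.3-fold higher number from compound 1 to compound 3 (0.12 log units; within the scatter), a small move toward a slightly higher number that may itself sit inside the scatter. Compound 3 is therefore estimated at 40 nM, with a range from 12 nM to 130 nM.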

Compound 3, half-maximal inhibitory concentration: 50 nM
Beside the measured number, compound 3's estimate is 1.3-fold (0.10 log units) below it, within the range that was stated.
By their numbers in this assay, from the lowest: compounds 2, 1 and 3 (each within the scatter of the next, the first and the last beyond it).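

Within the data shown here, this is the first step that isolates a single change at this position. In this assay, allyl in place of methylsulfanyl on a saturated chain carbon bound to a carbonyl carbon and a saturated chain carbon gives a 1.7-fold higher number from compound 1 to compound 3 (0.22 log units; within the scatter) and so does not separate the two groups on this read-out. The swap removes the sulfur atom and the one hydrogen-bond acceptor counted for methylsulfanyl and brings in an all-carbon group with a double bond, yet the two compounds remain within the usual scatter of repeated measurements, and nothing available explains this result.

The compounds shown leave open whether a hydroxyl group, an amine or a longer chain such as hexyl on this carbon would stay within the scatter of compound 1 or move beyond it. Among these compounds, this change is also seen in only one pair of compounds, so whether allyl and methylsulfanyl would again read alike on a different core remains an open question.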